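The source may hold more compounds than are shown below. What is called first, only, known or untested is meant among the compounds shown, and "the series" means these compounds.

Measured so far in a functional assay on Bel-7402 cells (Homo sapiens) for cytotoxicity, read by MTT assay; on this read-out higher numbers stand for weaker inhibition and lower numbers for stronger inhibition:

Compound 1 `CC(C)=CCCC(C)(O)c1ccc(C)cc1` — in this assay compound 1 gives > 10 ug/mL, which is a limit of the assay and not a number.

Compound 2 `Cc1ccc([C@]2(C)CC[C@H](C(C)(C)O)O2)cc1` — in this assay compound 2 gives > 10 ug/mL, likewise a limit of the assay and not a number.

Compound 2 therefore stands at the limit of > 10 ug/mL in this assay, at which 2 of the 2 values shown sit. Its result is a limit, so no number places it relative to compound 1, and the two values show only that both sit at the same limit; nothing can be read about any difference between them.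

Compound 3 `Cc1ccc([C@]2(C)CC[C@@H](C(C)(C)O)O2)cc1` is the next compound to be measured in this assay. Its relation to compound 2 is as follows: the two compounds have the same atoms and bonds and differ only in configuration as drawn: 1 of 2 stereo elements differ; a stereocentre at a saturated ring carbon is drawn R in compound 2 and S in compound 3. Among the compounds with values here, no step between two measured compounds exists here to show what such a change in configuration does to cytotoxicity. Because compound 2 sits at the limit of > 10 ug/mL in this assay, at which 2 of the 2 values shown sit, the expectation for compound 3 rests on that limit alone. The step from compound 2 to compound 3 is expected to be a step that the limit leaves unreadable from compound 2 to compound 3, nothing beyond the usual scatter. Compound 3 is therefore expected to give about 20 ug/mL in this assay, most likely again reported only as a limit, within a range from 8 ug/mL to 50 ug/mL.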

Compound 3, half-maximal inhibitory concentration: > 10 ug/mL
Compound 3: no number, only a limit (the forecaster's own chance of this, stated with the estimate: 85%); the middle value does not contradict the limit.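

No step can be read between compound 2 and compound 3 in this assay, since both results are limits and not numbers: the limit of > 10 ug/mL in this assay, at which 3 of the 3 values shown sit.

The compounds shown leave open whether the configuration at that saturated ring carbon changes cytotoxicity at all, and how strong any of the three compounds actually is.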